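A few compounds are considered here, and "the series" means these few. Any claim that something is new, unique, unknown or untested is made for them only; others in the source may bear on it.

Of the compounds shown here, two have been tested in a functional assay on PC-12 cells (Rattus norvegicus) for cytotoxicity, read by MTT assay, with stated times of 2 h and 24 h, tested at 5 uM; a lower number here means a weaker effect, a higher number a stronger effect of the compound at the concentration tested. Compound 1 `Oc1cc(C(F)(F)F)ccc1-c1nc(-c2ccccc2O)n(-c2ccc(Cl)cc2)n1` gives 87.3% there. For the measured compounds named here, compound 2 `Cc1cc(C)cc(-n2nc(-c3ccc(C(F)(F)F)cc3O)nc2-c2ccccc2O)c1` gives 102% in this assay, and its reading is the higher of the two, since the only measured step, a number 14.7 percentage points higher from compound 1 to compound 2 (beyond the scatter), lies beyond the scatter.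

Compound 3 `Oc1cc(C(F)(F)F)ccc1-c1nc(-c2ccccc2O)n(-c2cc(F)cc(F)c2)n1` has not been measured yet. It differs from compound 2 in one place: 3,5-difluorophenyl in place of 3,5-dimethylphenyl on an aromatic nitrogen. Going by the values given here, the one measured step bears on this change only loosely. It was made at the same place, and it swapped a chlorine-bearing phenyl for the dimethyl-bearing phenyl, raising the reading in this assay by a modest amount. Compound 3 moves the other way, from the dimethyl-bearing phenyl back to a halogen-bearing phenyl, though with two fluorines in a different arrangement. A modest fall or no change beyond the scatter therefore seems the most likely outcome, with the two fluorines giving no firm ground for more.

Compound 3 is expected to give about 92% in this assay, within 78% to 105%. This estimate amounts to an expected a number 10 percentage points lower from compound 2 to compound 3 (within the scatter).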

Compound 3, a percentage reported as activity, at one concentration (the size of the read-out at that concentration, not a potency): 100%
Estimate against measurement, compound 3: 8 percentage points below; the range from low to high includes it.
By their numbers in this assay, from the lowest: compound 1; then compounds 3 and 2 (each within the scatter of the next).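

In this assay, replacing 3,5-dimethylphenyl with 3,5-difluorophenyl on the aromatic nitrogen gives a number 2 percentage points lower from compound 2 to compound 3 (within the scatter), so this assay does not separate these two groups. Replacing 4-chlorophenyl with 3,5-difluorophenyl at the same place gives a number 12.7 percentage points higher from compound 1 to compound 3 (beyond the scatter), a modest step much like the one seen earlier with 3,5-dimethylphenyl, which shows that a halogen on this phenyl ring does not by itself go with the lower reading of compound 1. No measurement here explains why compound 1 stands apart from compound 2 and compound 3.

The 4-chlorophenyl and 3,5-difluorophenyl groups differ in the halogen, in the number of halogen atoms and in their arrangement, so the compounds shown leave open which of these matters; 4-fluorophenyl and 3,5-dichlorophenyl would help to pull those apart. They also leave open whether this position tolerates groups of a quite different kind, such as a phenyl ring carrying an amine or a carboxylic acid, or a longer chain in place of the ring.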